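This account rests on a few compounds, and the source may have more. Where it says the series, first, only, none or still open, it means among the compounds named here.

Of the compounds shown here, three sharing one core have been measured in an ADME assay on ECV-304 cells (Homo sapiens) for cytotoxicity, read by MTT assay, with a stated time of 72 h; a lower number here means a stronger inhibitor, a higher number a weaker inhibitor. Compound 1, `C=CCOc1cc(C2=C(c3cc(OC)c(OC)c(OC)c3)C(=O)C(O)C2)ccc1OC`, stands at the limit of > 100 ug/mL in this assay, at which 1 of the 3 values shown sits. In this assay compound 1 gives > 100 ug/mL, and this is a limit of the assay, not a number. The other two compounds give numbers. Compound 2, `COc1ccc(C2=C(c3cc(OC)c(OC)c(OC)c3)C(=O)C(O[SiH2]C(C)(C)C)C2)cc1`, gives 16 ug/mL in this assay, and compound 3, `COc1ccc(C2=C(c3cc(OC)c(OC)c(OC)c3)C(=O)CC2O[SiH2]C(C)(C)C)cc1O`, gives 30 ug/mL. None of these three compounds differs from another in a single place, so their values can only be read side by side, not as steps.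

The piece now follows the move from compound 1 to compound 4, `COc1ccc(C2=C(c3cc(OC)c(OC)c(OC)c3)C(=O)C(O)C2)cc1OC(C)C`, which has not yet been measured in this assay. Compound 4 differs from compound 1 in one place: isopropyl in place of allyl on an oxygen on an aromatic ring. The group that leaves and the group that enters are of the same size, and both sit on the same oxygen on an aromatic ring. Within the data shown here, with no measured step of this kind among the three compounds, the step is expected to be about a number no higher from compound 1 to compound 4 (the limit leaves the size open), that is, none beyond the usual scatter. Compound 4 is therefore expected to give about 100 ug/mL in this assay, within a range from 40 ug/mL to 300 ug/mL, most likely again as a limit rather than a number.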

Compound 4, half-maximal inhibitory concentration: > 100 ug/mL
Compound 4: only a limit was reported (the forecaster's own chance of this, stated with the estimate: 60%); the middle value sits exactly at the limit.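

In this assay compound 4 gives > 100 ug/mL, which is a limit of the assay and not a number. Compound 1 stands at the same limit, so no step can be read between compound 1 and compound 4: the limit of > 100 ug/mL in this assay, at which 2 of the 4 values shown sit. The compounds shown leave open how far past that limit either compound lies, and whether isopropyl in place of allyl changes the read-out at all.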